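Moving the Methoxy Group on the Amide Aryl

The source may hold more compounds than are shown below. What is called first, only, known or untested is meant among the compounds shown, and "the series" means these compounds.

Measured so far:
compound 1, `CCNC(=O)c1nc(-c2cc(OC)c(OC)c(OC)c2)n(-c2ccc(OC)cc2)n1`: 58%
compound 2, `COc1ccc(NC(=O)c2nc(-c3cc(OC)c(OC)c(OC)c3)n(-c3ccc(OC)cc3)n2)cc1`: 63%

In a functional assay on the whole organism for inhibition, with Rattus norvegicus as the target, read by paw edema, with stated times of 30 min and 4 h, at a dose of 0.28 mmol/kg by the oral route (a higher number here means more inhibition at the dose given (going by the name of the read-out), a lower number less inhibition), compound 1 gives 58%, and compound 2 gives 63%. Among the compounds with values here, the single measured step, a number 5 percentage points higher from compound 1 to compound 2 (within the scatter), puts 4-methoxyphenyl in place of ethyl on an amide-type nitrogen. Of the two numbers, that of compound 2 is the larger, but the gap to compound 1 is within the scatter, so the two compounds cannot be told apart on these data.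

Compound 3, `COc1ccc(-n2nc(C(=O)Nc3ccccc3OC)nc2-c2cc(OC)c(OC)c(OC)c2)cc1`, has not yet been measured. It differs from compound 2 by 2-methoxyphenyl in place of 4-methoxyphenyl on an amide-type nitrogen; the two have the same atoms, joined differently, so a (4-methoxyphenyl)carbamoyl group becomes a (2-methoxyphenyl)carbamoyl group. Within the data shown here, no measured step bears on this change: the only step available swaps ethyl for 4-methoxyphenyl and stayed within the scatter. On that basis compound 3 is expected to remain close to compound 2, the expected step being a number 5 percentage points lower from compound 2 to compound 3 (within the scatter). Compound 3 is therefore estimated at 58%, in a range from 40% to 75%.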

Compound 3, a percentage reported as inhibition, in the whole organism at one dose (the size of the read-out at that dose, not a potency): 24%
Beside the measured number, compound 3's estimate is 34 percentage points above it; measured number below the stated range.
By their numbers in this assay, from the lowest: compound 3; then compounds 1 and 2 (each within the scatter of the next).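

Replacing 4-methoxyphenyl with 2-methoxyphenyl on the amide-type nitrogen in this assay gives a number 39 percentage points lower from compound 2 to compound 3 (beyond the scatter), so at this position the two isomeric groups, which have the same atoms, cannot be treated as interchangeable. The earlier step from ethyl to 4-methoxyphenyl had stayed within the scatter, whereas 2-methoxyphenyl in place of ethyl gives a number 34 percentage points lower from compound 1 to compound 3 (beyond the scatter), which shows that the presence of an aryl group on this nitrogen does not by itself decide the outcome, since the 4-methoxyphenyl compound and the ethyl compound remain within the scatter of each other. Nothing available here explains why the placement of the methoxy group matters so much in this whole-animal measurement.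

The compounds shown leave open whether the loss follows from the methoxy group in the 2-methoxyphenyl arrangement specifically or would also appear with other groups there, such as a chlorine or a methyl on the ring. They also do not show how a plain phenyl or a benzyl group on the same nitrogen would compare with the ethyl and 4-methoxyphenyl amides.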